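Swapping a Dichlorophenyl Group for a Furan Ring

The source may report more compounds than this note shows. Statements on the series, on what has been measured and on what is new or still open speak of the compounds shown alone.

Compounds measured so far in a functional assay on IMR-32 cells (Homo sapiens) for cytotoxicity, read by sulforhodamine B assay, with a stated time of 48 h; a higher number here means a weaker inhibitor, a lower number a stronger inhibitor:
- compound 1 `CC(=O)N1N=C(c2cccc3ccccc23)CC1c1ccccc1` gives 7760 nM
- compound 2 `O=CCN1N=C(c2ccc3ccccc3c2)CC1c1ccccc1[N+](=O)[O-]` gives 3360 nM
- compound 3 `O=CCN1N=C(c2ccc3ccccc3c2)CC1c1cccc(Cl)c1Cl` gives 16900 nM

Compound 3 stands highest of the three numbers in this assay, which makes it the weakest inhibitor of the set; its nearest neighbor is compound 1, and compound 2 lies furthest from it. Going by the values given here, the only step between two compounds that differ in a single place is a 5.0-fold higher number from compound 2 to compound 3 (0.70 log units; beyond the scatter), showing that changing the ring on that saturated ring carbon can shift the number clearly beyond the scatter.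

Compound 4 `O=CCN1N=C(c2ccc3ccccc3c2)CC1c1ccco1` differs from compound 3 in one place: furan-2-yl in place of 2,3-dichlorophenyl on a saturated ring carbon. Among the compounds with values here, no measured step exchanges a six-membered aromatic ring for a five-membered one here, so the direction cannot be read from the data; the one comparable exchange, from compound 2 to compound 3, was modest in size. Compound 4 is therefore expected to fall somewhere in the span of the measured compounds, with a step of a 1.7-fold lower number from compound 3 to compound 4 (0.23 log units; within the scatter). The estimate for compound 4 in this assay is 10000 nM, expected to lie between 3000 nM and 35000 nM.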

Compound 4, half-maximal inhibitory concentration: 11000 nM
Compound 4: the middle estimate sits 1.1-fold (0.04 log units) below what was measured; the measured number falls inside the stated range.
By their numbers in this assay, from the lowest: compound 2; then compounds 1, 4 and 3 (each within the scatter of the next, the first and the last beyond it).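

In this assay the exchange gives a 1.5-fold lower number from compound 3 to compound 4 (0.19 log units; within the scatter), so on this saturated ring carbon a five-membered aromatic furan-2-yl ring cannot be told apart from the six-membered 2,3-dichlorophenyl ring. The second comparison, a 3.3-fold higher number from compound 2 to compound 4 (0.52 log units; beyond the scatter), shows that 2-nitrophenyl now stands apart from two different rings at this position, not just from 2,3-dichlorophenyl. No available evidence explains why these rings give the numbers they do.

The compounds shown leave open whether a group with no ring at this carbon, such as an amine or a longer alkyl chain, would stay in the same range. They also leave open whether the separation of compound 2 comes from the nitro group itself, which a carboxylic acid on the same phenyl ring could help to test.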